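Benzylamine aryl variation on the shared core

A few compounds are considered here, and "the series" means these few. Any claim that something is new, unique, unknown or untested is made for them only; others in the source may bear on it.

Compound 1 `Nc1nc(NCc2ccc(F)cc2)nc(-c2ccccc2CO)n1` gives 3.97 in a functional assay on cells for positive allosteric modulation of G-protein coupled receptor 68 (Homo sapiens), read by a luciferase reporter and cAMP accumulation, with a stated time of 30 min, at pH 6.8 and pH 8.3, in the presence of a further agent that is not named here; on this read-out higher numbers stand for higher potency (the scale is a negative logarithm) and lower numbers for lower potency.
Compound 2 `Nc1nc(NCc2ccccc2Cl)nc(-c2ccccc2CO)n1` gives 5.07 in this assay.
Compound 3 `COc1cccc(CNc2nc(N)nc(-c3ccccc3CO)n2)c1` gives 4.11 in this assay.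

Compound 1 holds the lowest number of the three. Compound 3 sits within the scatter of it, while compound 2 lies well beyond it, with a number 1.10 log units higher from compound 1 to compound 2 (beyond the scatter). Compound 4 `Nc1nc(NCc2ccc(OC3CC3)cc2)nc(-c2ccccc2CO)n1` carries cyclopropyloxy in place of fluoro on an aromatic carbon. For the measured compounds named here, no measured step keeps the fluoro-bearing ring and alters only one substituent on it; the known steps exchange the whole aryl group, with a number 1.10 log units higher from compound 1 to compound 2 (beyond the scatter) being large, a number 0.14 log units higher from compound 1 to compound 3 (within the scatter) within the scatter, and a number 0.96 log units lower from compound 2 to compound 3 (beyond the scatter). Going by the values given here, the change in compound 4 therefore has no direct precedent. For compound 4 a small shift in this assay is expected, a number 0.23 log units higher from compound 1 to compound 4 (within the scatter). Compound 4 is estimated at 4.2, range 3.6 to 4.9.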

Compound 4, negative logarithm of the antagonist equilibrium constant: 5.07
Compound 4: the middle estimate sits 0.87 log units below what was measured; measured number above the stated range.
By their numbers in this assay, from the lowest: compounds 1 and 3 (each within the scatter of the next); then compounds 2 and 4 (each within the scatter of the next).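

Replacing only the substituent, with the ring and its place kept, is enough to move the number: cyclopropyloxy in place of fluoro, para to a large group, gives a number 1.10 log units higher from compound 1 to compound 4 (beyond the scatter). Earlier, a step of this size came with an exchange of the whole aryl group, a number 1.10 log units higher from compound 1 to compound 2 (beyond the scatter). No measurement bearing on the origin of this step is available.

The compounds shown leave open whether the step follows the oxygen or the three-membered ring. A methoxy group, a plain cyclopropyl group or a longer alkoxy chain on this aromatic carbon would separate the two.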